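Compound 2 and the loss of its fluoro group

This account rests on a few compounds, and the source may have more. Where it says the series, first, only, none or still open, it means among the compounds named here.

In a functional assay on HeLa cells (Homo sapiens) for antiproliferative activity, read by MTT assay, with a stated time of 48 h (a higher number here means a weaker inhibitor, a lower number a stronger inhibitor), compound 1 `Cc1c(Cc2ccccc2)c(=O)oc2cc(OCCOc3no[n+]([O-])c3S(=O)(=O)c3ccccc3)ccc12` gives 22.9 nM and compound 2 `COc1cc(OCCOc2no[n+]([O-])c2S(=O)(=O)c2ccccc2)ccc1C(=O)/C=C/c1ccc(F)cc1` gives 6.9 nM. Compound 2 holds the lower of the two numbers, and the gap to compound 1 lies beyond the scatter. Compound 3 `COc1cc(OCCOc2no[n+]([O-])c2S(=O)(=O)c2ccccc2)ccc1C(=O)/C=C/c1ccccc1` differs from compound 2 in one place hydrogen in place of fluoro on an aromatic carbon, para to a large group. Going by the values given here, no measured pair shows this change, so only a small shift towards a higher number, within the scatter, is expected in this assay. The estimated size is a 1.3-fold higher number from compound 2 to compound 3 (0.12 log units; within the scatter). For compound 3 the expected value is 9 nM (estimated range 3 nM to 28 nM).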

Compound 3, half-maximal inhibitory concentration: 17.8 nM
Compound 3: the middle estimate sits 2.0-fold (0.30 log units) below what was measured, and the stated range covers the measured number.
By their numbers in this assay, from the lowest: compound 2; then compounds 3 and 1 (each within the scatter of the next).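

In this assay, going by these compounds alone, replacing fluoro with hydrogen para to a large group gives a 2.6-fold higher number from compound 2 to compound 3 (0.41 log units; beyond the scatter), the first measured pair to isolate this position. The step lies beyond the scatter, though it is modest, so the 4-fluorophenyl group holds the lower number of this pair. Nothing at hand accounts for the step.

On these data alone, whether chloro, methoxy or trifluoromethyl at this same place would match fluoro stays open. So does whether the step would carry over to a core other than the one shared by compound 2 and compound 3.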